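A Second Chloro Group on the Fused Ring System

The compounds below may be only part of what the source reports. "The series", "measured", "known", "first", "only" and "open" are said of these compounds alone.

Measured so far:
compound 1, `CCC1(CCCCN2CCN(c3ccc(F)cc3)CC2)C(=O)Nc2ccccc21`: 0.43 nM
compound 2, `CCC1(CCCCN2CCN(c3ccc(F)c(Cl)c3)CC2)C(=O)Nc2ccccc21`: 0.6 nM
compound 3, `CCC1(CCCCN2CCN(c3cccc(Cl)c3)CC2)C(=O)Nc2cc(F)ccc21`: 0.67 nM

In an assay on CHO cells for displacement of a labelled ligand from 5-hydroxytryptamine receptor 7 (Homo sapiens) (on this read-out lower numbers stand for stronger inhibition and higher numbers for weaker inhibition), compound 1 gives 0.43 nM, compound 2 gives 0.6 nM and compound 3 gives 0.67 nM. The change chloro in place of hydrogen on an aromatic carbon gave a 1.4-fold higher number from compound 1 to compound 2 (0.14 log units; within the scatter). The difference between the core of compound 1 and the core of compound 3 is not broken down here.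

Compound 4, `CCC1(CCCCN2CCN(c3cccc(Cl)c3)CC2)C(=O)Nc2cc(F)c(Cl)cc21`, has not yet been measured. It differs from compound 3 by chloro in place of hydrogen on an aromatic carbon. This is the same kind of change as before, but here the place lies on a ring that is part of a fused or bridged system of two rings, meta to a fused ring and para to a fused ring, whereas in compound 2 the place is meta to a large group. Because the earlier change gave a 1.4-fold higher number from compound 1 to compound 2 (0.14 log units; within the scatter), a similarly small step is expected, a 1.3-fold higher number from compound 3 to compound 4 (0.13 log units; within the scatter). Compound 4 is estimated at 0.9 nM, with a likely range from 0.4 nM to 2 nM.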

Compound 4, inhibition constant: 9.07 nM
Compound 4: the middle estimate sits 10-fold (1.00 log units) below what was measured; the whole stated range lies below it.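

In this assay, chloro in place of hydrogen on an aromatic carbon gave a 14-fold higher number from compound 3 to compound 4 (1.13 log units; beyond the scatter), so the change did not carry over from one core to the other at the same size: the same change on two cores in this assay, a 1.4-fold higher number (0.14 log units; within the scatter) from compound 1 to compound 2 and a 14-fold higher number (1.13 log units; beyond the scatter) from compound 3 to compound 4, 9.7-fold (0.99 log units) apart, beyond the scatter of two such steps

The step seen on one compound pair is therefore no safe guide to the step on another in this series. These two pairs do not show why the steps differ, since the chloro enters a different ring in each, and in compound 4 it stands ortho to a fluoro group.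

Going by these compounds, it remains open whether chloro at this place would give so large a step without that fluoro group. Also open, on these data alone, is whether a methyl or methoxy group there would behave like chloro.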